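Compound 4: a chloropyridyl in place of a fluorophenyl

A few compounds are considered here, and "the series" means these few. Any claim that something is new, unique, unknown or untested is made for them only; others in the source may bear on it.

Compound 1 `CCOc1ccccc1-c1nnc(SCCn2c([N+](=O)[O-])cnc2C)o1` gives 9800 nM in a functional assay on HepG2 cells (Homo sapiens) for cytotoxicity, read by MTT assay, with a stated time of 48 h; on this read-out higher numbers stand for weaker inhibition and lower numbers for stronger inhibition.
Compound 2 `Cc1ncc([N+](=O)[O-])n1CCSc1nnc(-c2ccccc2F)o1` gives 3700 nM in this assay.
Compound 3 `COc1ccc(-c2nnc(SCCn3c([N+](=O)[O-])cnc3C)o2)c(O)c1` gives 11000 nM in this assay.

Compound 2 has the lowest number of the three. The step from compound 1 to compound 2 is a 2.6-fold lower number from compound 1 to compound 2 (0.42 log units; beyond the scatter), a fluoro in place of an ethoxy on an aromatic carbon. Among the measured compounds shown here, compound 3, with 11000 nM, also sits above compound 2, though no single-point step links those two.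

Compound 4 `Cc1ncc([N+](=O)[O-])n1CCSc1nnc(-c2ccnc(Cl)c2)o1` differs from compound 2 in one place: 2-chloropyridin-4-yl in place of 2-fluorophenyl on an aromatic carbon. For the measured compounds named here, the only measured step, from compound 1 to compound 2, changes a substituent on the ring that stays in place; it does not exchange the ring itself, so no measured step speaks to the change at hand. With nothing to lean on, a step within the scatter, or at most a modest rise, is expected. Compound 4 is therefore estimated at 5000 nM in this assay, within 1500 nM to 16000 nM, an expected step of a 1.4-fold higher number from compound 2 to compound 4 (0.13 log units; within the scatter).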

Compound 4, half-maximal inhibitory concentration: 11600 nM
The estimate for compound 4 lay 2.3-fold (0.37 log units) below the measured number; measured number inside the range.
By their numbers in this assay, from the lowest: compound 2; then compounds 1, 3 and 4 (each within the scatter of the next).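

Exchanging the ring itself at this place on the five-membered aromatic ring, with 2-chloropyridin-4-yl in place of 2-fluorophenyl, gives a 3.1-fold higher number from compound 2 to compound 4 (0.50 log units; beyond the scatter) in this assay. Among the compounds shown here, the earlier step changed only a substituent on a ring that stayed in place, so this is the first sign that the identity of the ring at this position also moves the number, here upward and beyond the scatter. No measurement on hand accounts for this rise.

The change alters the ring nitrogen, the halogen and the point of attachment all at once, and the compounds shown cannot divide the step among them. From the compounds shown here alone, a chlorophenyl or a pyridyl ring without chlorine at this position would be needed to separate those parts, and whether an amine on the pyridyl ring would shift the number remains open.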